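The source may hold more compounds than are shown below. What is called first, only, known or untested is meant among the compounds shown, and "the series" means these compounds.

Measured in an ADME assay on CCRF-HSB-2 cells (Homo sapiens) for cytotoxicity, with a stated time of 7 days; on this read-out lower numbers stand for higher toxicity in this test and higher numbers for lower toxicity in this test:
- Compound 1 `Nc1nc(OCc2ccccc2)c2ncn(/C=C3/CC3(CO)CO)c2n1`: > 20000 nM, a limit.
- Compound 2 `Nc1nc(NC2CCCC2)c2ncn(/C=C3/CC3(CO)CO)c2n1`: > 20000 nM, a limit.
- Compound 3 `CCCCCCCCSc1nc(N)nc2c1ncn2/C=C1/CC1(CO)CO`: 60000 nM.

Within the data shown here, compound 3 holds the only actual number, and the rest is the limit of > 20000 nM in this assay, at which 2 of the 3 values shown sit. Compound 4 `CSc1nc(N)nc2c1ncn2/C=C1/CC1(CO)CO` differs from compound 3 as follows: hydrogen in place of heptyl on a saturated chain carbon bound to a sulfur. This turns octylsulfanyl into methylsulfanyl.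

Among the measured compounds shown here, two measured steps bear on this, a step that the limit leaves unreadable from compound 1 to compound 3 and a step that the limit leaves unreadable from compound 2 to compound 3. Both replace the group on the aromatic carbon, but neither has a readable size. They therefore supply no size or direction, and no change beyond the usual scatter is expected in this assay. The estimated change is no change at the digits printed from compound 3 to compound 4 (within the scatter). For compound 4 the expected value is 60000 nM, with an estimated range from 20000 nM to 150000 nM.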

Compound 4, half-maximal cytotoxic concentration: > 100000 nM
Compound 4: a limit, no number; the forecaster's own chance of this, stated with the estimate: 50%; middle value at least 1.6-fold (0.22 log units) away from the limit.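

In this assay, among these compounds, replacing octylsulfanyl with methylsulfanyl gives the first step at this position that has a direction, an at least 1.6-fold higher number from compound 3 to compound 4 (0.22 log units; that floor lies within the scatter). Its size remains only a floor because the value of compound 4 is a limit: the limit of > 100000 nM in this assay, at which 1 of the 4 values shown sits. The steps from compound 1 and compound 2 to compound 4 cannot be read.

The compounds shown leave open where a butylsulfanyl group would fall between the octylsulfanyl and methylsulfanyl groups. They also leave open how a methoxy group or a methylamino group would compare with methylsulfanyl on the same aromatic carbon.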